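Swapping Hydroxymethyl for Methylsulfanyl on an Aromatic Carbon

This account rests on a few compounds, and the source may have more. Where it says the series, first, only, none or still open, it means among the compounds named here.

Compound 1 `CNC[C@]1(O)Cc2ccccc2[C@@H]1Oc1ccccc1CO` is the starting point of this account, but in an in vitro ADME assay on microsomes from liver (Rattus norvegicus) for metabolic stability (on this read-out lower numbers stand for slow clearance and higher numbers for fast clearance), compound 1 stands at "not determined" (no result reported) and so offers no number to build on. Two relatives sharing its core do provide numbers. Compound 2 `CNC[C@]1(O)Cc2ccccc2[C@@H]1Oc1ccc(O)cc1C` gives 10 mL/min/kg in this assay and compound 3 `CNC[C@]1(O)Cc2ccccc2[C@@H]1Oc1ccccc1-c1cccc2ccccc12` gives 23 mL/min/kg; 23 mL/min/kg (2 entries) in the same test.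

The compound of interest is compound 4 `CNC[C@]1(O)Cc2ccccc2[C@@H]1Oc1ccccc1SC` which differs from compound 1 in one place. The change is methylsulfanyl in place of hydroxymethyl on an aromatic carbon and it falls on an aromatic carbon of a six-membered aromatic ring of carbon only, ortho to a large group. In words, methylsulfanyl takes the place of hydroxymethyl.

For the measured compounds named here, no measured pair shows this exchange, and without a number for compound 1 the size of the step cannot be read directly. The expectation in this assay is therefore modest: no shift in either direction beyond the usual scatter from the range set by the two measured relatives, with compound 2 at 10 mL/min/kg and compound 3 at 23 mL/min/kg; 23 mL/min/kg (2 entries) as its guides. In this assay compound 4 is estimated at 20 mL/min/kg with an expected range from 9 mL/min/kg to 45 mL/min/kg as the likely outcome.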

Compound 4, clearance: 43 mL/min/kg
Estimate against measurement, compound 4: 2.2-fold (0.33 log units) below, within the range that was stated.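

In this assay, for the compounds shown here, compound 1 offers no number to set against compound 4, so no step between the two can be read. No evidence on hand bears on the value of compound 4. The compounds shown leave open how far, and in which direction, methylsulfanyl in place of hydroxymethyl shifts clearance.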